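Moving the methoxy group of compound 3

The source may hold more compounds than are shown below. What is called first, only, known or untested is meant among the compounds shown, and "the series" means these compounds.

For the measured compounds named here, in a functional assay on HL-60 cells (Homo sapiens) for antiproliferative activity, read by MTT assay, with a stated time of 72 h (a lower number here means a stronger inhibitor, a higher number a weaker inhibitor), compound 3 (`COc1ccc(-c2ncnn2-c2cc(OC)c(OC)c(OC)c2)cc1`) gives 120 nM, the only number so far in this small series. Compound 1 (`COc1cc(-c2ncnn2-c2ccc(Cl)cc2Cl)cc(OC)c1OC`) gives > 10000 nM, which is a limit. Compound 2 (`COc1cc(-c2ncnn2-c2cccc(N)c2)cc(OC)c1OC`) gives > 10000 nM, also a limit. Going by the values given here, the one measured step, a step that the two limits leave unreadable from compound 1 to compound 2, therefore has no size to carry over. The record for the series comes down to this: the limit of > 10000 nM in this assay, at which 2 of the 3 values shown sit.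

Compound 4 (`COc1cccc(-c2ncnn2-c2cc(OC)c(OC)c(OC)c2)c1`) has the same atoms as compound 3, joined differently: 3-methoxyphenyl in place of 4-methoxyphenyl on an aromatic carbon. The methoxy group moves, while the rest of the structure stays as it is. Among the compounds with values here, no measured step tests this change, so any expectation of its size is a judgement and not a reading from the series. Compound 1 and compound 2 show only that other substitution patterns in this series can end at a limit. A sizeable loss from the value of compound 3, 120 nM, is therefore a real possibility.

The expected move, a 13-fold higher number from compound 3 to compound 4 (1.10 log units; beyond the scatter), is a weakening beyond the usual scatter, with wide uncertainty. For compound 4 the estimated value in this assay is 1500 nM, with an expected range of 200 nM to 10000 nM.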

Compound 4, half-maximal inhibitory concentration: > 10000 nM
Compound 4 ended at the assay's limit; the forecaster's own chance of this, stated with the estimate: 20%; at least 6.6-fold (0.82 log units) between middle value and limit.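

In this assay the placing of the methoxy group on the phenyl ring now has a readable effect: 3-methoxyphenyl in place of 4-methoxyphenyl gives an at least 83-fold higher number from compound 3 to compound 4 (1.92 log units; beyond the scatter) as a large step beyond the scatter. Compound 3 and compound 4 have the same atoms, joined differently, so this single change on an aromatic carbon of the five-membered ring is enough to take the series from a measured number to a limit, whereas the step from compound 1 to compound 2 cannot be read and said nothing about this position. Compound 4 gives > 10000 nM, which is a limit, and with it the series record reads: the limit of > 10000 nM in this assay, at which 3 of the 4 values shown sit.

As far as these compounds go, how far the true value of compound 4 lies past that limit stays open, so the step has a minimum size and no upper one. Also open, from the compounds shown here alone, is whether a hydroxyl, an ethoxy or a dimethylamino group in place of the methoxy of the 4-methoxyphenyl would hold the level of compound 3, 120 nM, in this assay.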